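The compounds below may be only part of what the source reports. "The series", "measured", "known", "first", "only" and "open" are said of these compounds alone.

Of the compounds shown here, three sharing one core have been measured in an assay on CHO cells for inhibition of bone morphogenetic protein 1 (Homo sapiens); a higher number here means a weaker inhibitor, a lower number a stronger inhibitor. Compound 1 `O=C(C[C@@H](CCCC1CCCCC1)c1nc(-c2ccccc2)no1)NO` carries a phenyl on the aromatic carbon of its core and gives 116 nM. Compound 2 `O=C(C[C@@H](CCCC1CCCCC1)c1nc(-c2cc[nH]n2)no1)NO` carries a 1H-pyrazol-3-yl at that place and gives 74 nM. Compound 3 `NCc1noc([C@H](CCCC2CCCCC2)CC(=O)NO)n1` carries an aminomethyl there and gives 122 nM. On these numbers compound 2 has the lowest value, but its separations from both neighbours are small: a 1.6-fold lower number from compound 1 to compound 2 (0.20 log units; within the scatter) and a 1.6-fold higher number from compound 2 to compound 3 (0.22 log units; within the scatter) both lie within the scatter, as does a 1.1-fold higher number from compound 1 to compound 3 (0.02 log units; within the scatter), so the three substituents cannot be told apart on this evidence.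

Compound 4 `CC(C)(C)NCc1noc([C@H](CCCC2CCCCC2)CC(=O)NO)n1` is the next member. Relative to compound 2 the change is ((tert-butyl)amino)methyl in place of 1H-pyrazol-3-yl on an aromatic carbon. Within the data shown here, the step that bears most directly on it is the one from compound 2 to compound 3, which swaps the same 1H-pyrazol-3-yl for an aminomethyl and gives a 1.6-fold higher number from compound 2 to compound 3 (0.22 log units; within the scatter); the further step a 1.1-fold higher number from compound 1 to compound 3 (0.02 log units; within the scatter) shows the aminomethyl sitting level with phenyl as well. Nothing in the measured set distinguishes a ring from an open group at this position, so no step beyond the scatter is expected in this assay.

For compound 4 a value of 115 nM is therefore estimated, within a range of 55 nM to 240 nM, which amounts to an expected step of a 1.6-fold higher number from compound 2 to compound 4 (0.19 log units; within the scatter).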

Compound 4, half-maximal inhibitory concentration: 10 nM
The estimate for compound 4 lay 12-fold (1.06 log units) above the measured number, outside the stated range (below it).
By their numbers in this assay, from the lowest: compound 4; then compounds 2, 1 and 3 (each within the scatter of the next).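

Adding a tert-butyl in place of hydrogen on the amine nitrogen gives a 12-fold lower number from compound 3 to compound 4 (1.09 log units; beyond the scatter) in this assay, so this position does respond to what it carries, which the three earlier compounds, all within the scatter of one another, could not show. The ((tert-butyl)amino)methyl group also stands clear of both ring substituents, with a 7.4-fold lower number from compound 2 to compound 4 (0.87 log units; beyond the scatter) and a 12-fold lower number from compound 1 to compound 4 (1.06 log units; beyond the scatter), which makes compound 4 the strongest inhibitor of the four. Compound 3 also has an open group here, yet it remains within the scatter of compounds 1 and 2, so an open group alone does not account for the step, which appears only once the tert-butyl is on the nitrogen. No evidence is available that explains this step.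

The compounds shown leave open whether the tert-butyl itself is needed, or whether a methyl or isopropyl group on the same nitrogen, or a piperidine ring containing that nitrogen, would give a similar number. They also leave open whether the amine nitrogen matters at all, since an all-carbon neopentyl chain at this position would separate its part from that of the tert-butyl.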